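A few compounds are considered here, and "the series" means these few. Any claim that something is new, unique, unknown or untested is made for them only; others in the source may bear on it.

Measured in a functional assay on MCF7 cells (Homo sapiens) for antiproliferative activity, read by MTT assay, with a stated time of 24 h; a higher number here means a weaker inhibitor, a lower number a stronger inhibitor:
Compound 1, `Brc1ccc(-c2nnc(Cn3nnc4ccccc43)o2)cc1`: 387000 nM
Compound 2, `COc1cccc(-c2nnc(Cn3nnc4ccccc43)o2)c1`: 370000 nM
Compound 3, `COc1ccc(-c2nnc(Cn3nnc4ccccc43)o2)cc1`: 376000 nM

Compound 3 gives the second highest of the three numbers in this assay, but its distances to compound 2 and to compound 1 both fall within the scatter, so no order among the three can be read. For the measured compounds named here, the only single-point step, a 1.0-fold lower number from compound 1 to compound 3 (0.01 log units; within the scatter), shows that replacing bromo by methoxy on the aromatic carbon leaves the number where it was. Compound 2 and compound 3 differ only in where the methoxy sits, and their two values show no difference either.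

Compound 4, `O=[N+]([O-])c1ccc(-c2nnc(Cn3nnc4ccccc43)o2)cc1`, has not been measured. The change from compound 3 is nitro in place of methoxy on an aromatic carbon. Going by the values given here, no measured step involves a nitro group, and the one step that exists, from bromo to methoxy, was flat; nothing points to a shift. For compound 4 the expected step is therefore a 1.0-fold higher number from compound 3 to compound 4 (0.00 log units; within the scatter), none beyond the scatter. The estimate for compound 4 in this assay is 380000 nM, in the range 150000 nM to 950000 nM.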

Compound 4, half-maximal inhibitory concentration: 13000 nM
Beside the measured number, compound 4's estimate is 29-fold (1.47 log units) above it, outside the stated range (below it).
By their numbers in this assay, from the lowest: compound 4; then compounds 2, 3 and 1 (each within the scatter of the next).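

In this assay, bromo and methoxy on this aromatic carbon, para to a large group, gave no readable difference, so the position looked insensitive to its substituent. Nitro shows otherwise, with a 29-fold lower number from compound 3 to compound 4 (1.46 log units; beyond the scatter) and a 30-fold lower number from compound 1 to compound 4 (1.47 log units; beyond the scatter), and the two steps agree, so the size of the change does not depend on which of the two earlier groups nitro replaces. No evidence at hand bears on the cause of this step.

From the compounds shown here alone, whether the large step belongs to nitro alone or would also appear with another group at this place, such as a nitrile, a carboxylic acid or an amine, stays open. Also open, going by these compounds, is whether nitro keeps the step where compound 2 carries its methoxy, and whether changes to the shared core would add to it.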